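The source may hold more compounds than are shown below. What is called first, only, known or untested is meant among the compounds shown, and "the series" means these compounds.

Measured so far in an assay for inhibition of Tryptophan 2,3-dioxygenase (Homo sapiens), with a stated time of 1 h, tested at 10 uM; on this read-out higher numbers stand for more inhibition at the one concentration tested (going by the name of the read-out) and lower numbers for less inhibition:
compound 1 `Oc1cccc(CNc2cc(Br)cc3[nH]ncc23)c1` gives 55%
compound 2 `ONc1cccc(CNc2cc(Br)cc3[nH]ncc23)c1` gives "not active" (no number reported)
compound 3 `CCOC(=O)Nc1cccc(CNc2cc(Br)cc3[nH]ncc23)c1` gives "not active" (no number reported)

All three compounds share the same core and differ only in the group attached to the outer ring. Among the measured compounds shown here, compound 1 is the only one with a number; compound 2 and compound 3 are recorded as inactive with no figure at all. Compound 3 therefore stands at the bottom of what has been seen, and there is no value from which to size a step away from it.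

The next compound, compound 4 `O=C1CCCC(Nc2cccc(CNc3cc(Br)cc4[nH]ncc34)c2)C1`, changes compound 3 in one place: 3-oxocyclohexyl in place of ethoxycarbonyl on a nitrogen on an aromatic ring. For the measured compounds named here, no pair of measured compounds in this set differs by such a change, so the size of the step cannot be read off from earlier numbers. What can be said is that compound 3 gave "not active" (no number reported), while compound 1 shows that this core can give 55%. A move in the direction of more inhibition, larger than the usual scatter, is expected but with wide uncertainty.

For compound 4 the estimated value in this assay is 30%, expected to lie between 0% and 65%.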

Compound 4, a percentage reported as inhibition, at one concentration (the size of the read-out at that concentration, not a potency): 46%
Estimate against measurement, compound 4: 16 percentage points below; the measured number falls inside the stated range.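

In this assay compound 2 and compound 3 are both recorded as "not active", yet compound 4 gives 46%, so a nitrogen on the aromatic ring does not by itself rule out a measurable read-out, although compound 2 and compound 3 show that not every group on that nitrogen gives one. The read-out shows a number 9 percentage points lower from compound 1 to compound 4 (within the scatter), so (3-oxocyclohexyl)amino and hydroxy cannot be told apart at this place, even though the first brings a whole six-membered ring where the second has none. Compound 3 has no number, so no step from it can be read, and nothing shown accounts for the contrast between these groups.

From the compounds shown here alone, what stays open is which part of the 3-oxocyclohexyl group matters: a plain cyclohexyl without the carbonyl, or a 3-hydroxycyclohexyl, would separate the role of the ring from that of the carbonyl. It is also open whether a bare amine or a short ethyl chain on the same nitrogen would give a number at all, and a reading at one concentration does not give a potency for any of these compounds.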